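From Methoxy to Ethoxy: One Added Methyl

The source may hold more compounds than are shown below. What is called first, only, known or untested is meant among the compounds shown, and "the series" means these compounds.

In a functional assay on Jurkat cells (Homo sapiens) for inhibition, read by MTT assay, with a stated time of 72 h (on this read-out higher numbers stand for weaker inhibition and lower numbers for stronger inhibition), compound 1 (`C=C(Br)C(=O)Nc1cccc(/C=C/C(=O)Nc2ccc(C)cc2)c1`) gives 240 nM and compound 2 (`C=C(Br)C(=O)Nc1cccc(/C=C/C(=O)Nc2ccc(OC)cc2)c1`) gives 470 nM so the two cannot be told apart. Compound 3 (`C=C(Br)C(=O)Nc1cccc(/C=C/C(=O)Nc2ccc(OCC)cc2)c1`) differs from compound 2 by methyl in place of hydrogen on a saturated chain carbon bound to an oxygen on an aromatic ring which turns methoxy into ethoxy. Within the data shown here, the only measured step that bears on this is a 2.0-fold higher number from compound 1 to compound 2 (0.29 log units; within the scatter) with methoxy in place of methyl on an aromatic carbon. That step stayed within the scatter, so no larger change is expected here. The expected change is a 1.0-fold lower number from compound 2 to compound 3 (0.02 log units; within the scatter) and it is estimated to stay within the scatter. For compound 3 the expected value is 450 nM with an estimated range from 200 nM to 1000 nM in this assay.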

Compound 3, half-maximal inhibitory concentration: 930 nM
The estimate for compound 3 lay 2.1-fold (0.32 log units) below the measured number; the measured number falls inside the stated range.
By their numbers in this assay, from the lowest: compounds 1, 2 and 3 (each within the scatter of the next, the first and the last beyond it).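

In this assay the added methyl gives a 2.0-fold higher number from compound 2 to compound 3 (0.30 log units; within the scatter) and so stays within the scatter on its own. Ethoxy in place of methyl on the aromatic carbon gives a 3.9-fold higher number from compound 1 to compound 3 (0.59 log units; beyond the scatter) and is the first step shown to pass beyond the scatter, a modest one, so this position separates ethoxy from methyl where methoxy had not done so. Nothing available explains this difference. As far as these compounds go, whether a longer chain such as propoxy would raise the number further remains open, as does the effect of an amine at this position.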